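A Cyclohexyl Swap on an Amine Nitrogen

The compounds below may be only part of what the source reports. "The series", "measured", "known", "first", "only" and "open" are said of these compounds alone.

Results so far in a functional assay on HeLa cells (Homo sapiens) for inhibition, with a stated time of 72 h; a lower number here means that less compound is needed, a higher number that more compound is needed for the effect
- compound 1 `COc1cc(CNC2CCCCC2)ccc1OCc1ccc(Cl)nc1` gives "nd(insoluble)" (no result reported)
- compound 2 `COc1cc(CNCc2ccncc2)ccc1OCc1ccc(Cl)c(Cl)c1` gives 4000 nM

Compound 1 has no place on the scale of this assay, as compound 1 gives only "nd(insoluble)" (no result reported) and no number. Compound 3 `COc1cc(CNCc2cccnc2)ccc1OCc1ccc(Cl)nc1` carries (pyridin-3-yl)methyl in place of cyclohexyl on an amine nitrogen. Within the data shown here, no measured step shows what this change does, so its size from compound 1 cannot be judged. Among the measured compounds shown here, the only number available is that of compound 2 at 4000 nM, and a result within the usual scatter of it is expected. For compound 3 the estimated value is 5000 nM (expected range 1500 nM to 20000 nM).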

Compound 3, half-maximal effective concentration: 5000 nM
Estimate against measurement, compound 3: no gap at the digits printed; the range from low to high includes it.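

Among these compounds, compound 1 has no number, so no step from compound 1 to compound 3 can be read. Going by these compounds, what replacing cyclohexyl with (pyridin-3-yl)methyl does to the value stays open. No measured evidence bears on this result.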